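The source may hold more compounds than are shown below. What is called first, only, known or untested is meant among the compounds shown, and "the series" means these compounds.

In a functional assay on KKU-M214 cells (Homo sapiens) for cytotoxicity, read by MTT assay (on this read-out lower numbers stand for stronger inhibition and higher numbers for weaker inhibition), compound 1 `Cc1cc(O)c(C=O)c2c1C(=O)Oc1c(O)c3c(c(C)c1O2)C(=O)CC(C)(C)O3` gives 5.05 ug/mL and compound 2 `Cc1cc(O)c(C=O)c2c1C(=O)Oc1c(cc3c(c1C)C(=O)CC(C)(C)O3)O2` gives 4.5 ug/mL on the same read-out. Going by the values given here, these two numbers lie within the usual scatter of each other, so compound 1 stands level with the only other measured compound. Compound 3 `Cc1c2c(c(O)c3c1C(=O)CC(C)(C)O3)OC(=O)c1c(C)c(Cl)c(O)c(C=O)c1O2` keeps the core of compound 1 with one change, chloro in place of hydrogen on an aromatic carbon. Among the compounds with values here, no measured pair here shows what this swap does, so any expectation is a loose one. A single new atom on an otherwise unchanged structure is expected to move the number only modestly. The estimated step of a 1.4-fold lower number from compound 1 to compound 3 (0.16 log units; within the scatter) is small, points toward stronger inhibition and may not clear the scatter. In this assay compound 3 is expected to read 3.5 ug/mL (estimated range 1.5 ug/mL to 8 ug/mL).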

Compound 3, half-maximal inhibitory concentration: 4.4 ug/mL
Estimate against measurement, compound 3: 1.3-fold (0.10 log units) below; low and high end bracket the measured number.
By their numbers in this assay, from the lowest: compounds 3, 2 and 1 (each within the scatter of the next).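

In this assay the swap of hydrogen for chloro on an aromatic carbon gives a 1.1-fold lower number from compound 1 to compound 3 (0.06 log units; within the scatter) and so leaves no difference that can be told apart from the scatter of repeated measurements. This position, ortho to a hydroxy group and ortho to a methyl group, therefore accepts a chlorine atom while the cytotoxicity of the core of compound 1 stays on the same level. Nothing at hand gives a reason for this outcome.

From the compounds shown here alone, whether a different group at this position, such as an amine, a methoxy group or a longer chain, would move the number stays open. One swap also cannot show whether bromo or fluoro there would read the same way.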